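The compounds below may be only part of what the source reports. "The series", "measured", "known", "first", "only" and "open" are said of these compounds alone.

Compound 1 `COc1ccc(-c2cc(=O)c3c(OC)cc(OC)cc3n2S(=O)(=O)c2cccc([N+](=O)[O-])c2)cc1` gives > 39600 nM in a functional assay on HepG2 cells (Homo sapiens) for antiproliferative activity, with a stated time of 72 h (on this read-out lower numbers stand for an effect already at smaller amounts and higher numbers for an effect only at larger amounts of compound), which is a limit of the assay rather than a number.
Compound 2 `COc1ccc(-c2cc(=O)c3c(OC)cc(OC)cc3n2S(=O)(=O)c2ccc(C)c([N+](=O)[O-])c2)cc1` gives > 51700 nM in this assay, likewise a limit.

Among the measured compounds shown here, compound 2 thus sits at a limit, as does compound 1, and the only measured step, a step that the two limits leave unreadable from compound 1 to compound 2, cannot be read because both ends are limits (the limit of > 39600 nM in this assay, at which 1 of the 2 values shown sits, and (the limit of > 51700 nM in this assay, at which 1 of the 2 values shown sits)). Compound 3 `COc1ccc(-c2cc(=O)c3c(OC)cc(OC)cc3n2S(=O)(=O)c2c(F)c(F)c(F)c(F)c2F)cc1` differs from compound 2 by 2,3,4,5,6-pentafluorophenyl in place of 4-methyl-3-nitrophenyl on a sulfonyl sulfur. For the measured compounds named here, no measured step bears on this change, so no direction can be drawn from the data. Compound 3 is expected to stay near the limit, with an estimated 45000 nM between 12000 nM and 120000 nM. The expected step is an at least 1.1-fold lower number from compound 2 to compound 3 (0.06 log units; that floor lies within the scatter).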

Compound 3, half-maximal effective concentration: > 34400 nM
Compound 3: only a limit was reported (the forecaster's own chance of this, stated with the estimate: 70%); the middle value does not contradict the limit.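

Among the compounds shown here, compound 1, compound 2 and compound 3 each give only a limit, so no step among them can be read. Going by these compounds, whether the group on the sulfonyl sulfur changes the result in this assay at all stays open.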